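The source may hold more compounds than are shown below. What is called first, only, known or untested is meant among the compounds shown, and "the series" means these compounds.

Measured compounds:
- Compound 1 `CNc1nc(Nc2ccc(C)c(N)c2)ncc1C(=O)Nc1cc(NC(=O)c2ccccc2OC)ccc1C`: in an ADME assay on BaF3 cells (Mus musculus) for antiproliferative activity, read by CellTiter-Glo and CCK-8 assay, with a stated time of 72 h (a lower number here means a stronger inhibitor of growth, a higher number a weaker inhibitor of growth), compound 1 gives > 10000 nM, which is a limit of the assay and not a number.
- Compound 2 `CNc1nc(Nc2ccc(C)c(N)c2)ncc1C(=O)Nc1cc(NC(=O)c2cccc(OC)c2)ccc1C`: in this assay compound 2 gives > 10000 nM, again a limit.
- Compound 3 `CNc1nc(Nc2ccc(C)c(N)c2)ncc1C(=O)Nc1cc(NC(=O)c2cc(OC)cc(OC)c2)ccc1C`: in this assay compound 3 gives > 10000 nM, also a limit.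

Compound 3 therefore stands where every measured compound stands: at the limit of > 10000 nM in this assay, at which 3 of the 3 values shown sit, so no ordering among the three can be read. The steps between them carry no readable size: a step that the two limits leave unreadable from compound 1 to compound 2, a step that the two limits leave unreadable from compound 1 to compound 3 and a step that the two limits leave unreadable from compound 2 to compound 3 all run from one limit to another.

The unmeasured compound 4 `CNc1nc(Nc2ccc(C)c(N)c2)ncc1C(=O)Nc1cc(NC(=O)c2cc(OC)c(OC)c(OC)c2)ccc1C` differs from compound 3 in one place: methoxy in place of hydrogen on an aromatic carbon. The nearest measured comparison is the step from compound 2 to compound 3, which is the same kind of change (a methoxy entering an aromatic carbon), and its size is unreadable for the reason given by the limit of > 10000 nM in this assay, at which 3 of the 3 values shown sit. Nothing in the data suggests that this added methoxy moves the result off the limit, so the expected step that the limit leaves unreadable from compound 3 to compound 4 is none beyond the scatter. Compound 4 is thus estimated at 15000 nM, with a range from 4000 nM to 60000 nM, most probably reported only as a limit again.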

Compound 4, concentration for 50% growth inhibition: > 10000 nM
Compound 4: a limit, no number (the forecaster's own chance of this, stated with the estimate: 85%); the middle value is on the limit's open side.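

In this assay compound 4 gives > 10000 nM, which is a limit and not a number. Its steps to compound 1, compound 2 and compound 3 therefore cannot be read, since each runs from one limit to another: the limit of > 10000 nM in this assay, at which 4 of the 4 values shown sit. The compounds shown leave open which change, if any, would bring growth inhibition to a readable value.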